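The source may report more compounds than this note shows. Statements on the series, on what has been measured and on what is new or still open speak of the compounds shown alone.

Compound 3 (`O[C@H](COCCOC[C@@H](O)Cc1cn(Cc2cccc(-c3ccccc3)c2)nn1)Cc1ccc(-c2ccccc2)cc1`) gives 10600 nM in a functional assay on SGC-7901 cells (Homo sapiens) for inhibition, read by MTT assay, with a stated time of 72 h; a higher number here means a weaker inhibitor of growth, a lower number a stronger inhibitor of growth. Among the three compounds measured there, compound 1 (`CC1=C(C)C(=O)C(CCCCCCCCCCn2cc(C[C@H](O)COCCOC[C@@H](O)Cc3ccc(-c4ccccc4)cc3)nn2)=C(C)C1=O`), at 350 nM, and compound 2 (`CC1=C(CCCCCCCCCCn2cc(C[C@H](O)COCCOC[C@@H](O)Cc3ccc(-c4ccccc4)cc3)nn2)C(=O)c2ccccc2C1=O`), at 390 nM, both return far lower numbers, so compound 3 stands highest of the three, beyond the scatter from either. Compound 4 (`N#Cc1ccc(Cn2cc(C[C@H](O)COCCOC[C@@H](O)Cc3ccc(-c4ccccc4)cc3)nn2)cc1`) differs from compound 3 by 4-cyanophenyl in place of 3-phenylphenyl on a saturated chain carbon bound to an aromatic nitrogen. Going by the values given here, no measured pair isolates this change, so its direction cannot be read from the data; the expected step from compound 3 to compound 4 is a 1.1-fold higher number from compound 3 to compound 4 (0.05 log units; within the scatter), a shift not expected to go beyond the scatter. For compound 4 the estimate in this assay is 12000 nM, expected to lie between 4000 nM and 36000 nM.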

Compound 4, concentration for 50% growth inhibition: 7700 nM
Estimate against measurement, compound 4: 1.6-fold (0.19 log units) above, and the stated range covers the measured number.
By their numbers in this assay, from the lowest: compounds 1 and 2 (each within the scatter of the next); then compounds 4 and 3 (each within the scatter of the next).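

In this assay, 4-cyanophenyl in place of 3-phenylphenyl on a saturated chain carbon bound to an aromatic nitrogen gives a 1.4-fold lower number from compound 3 to compound 4 (0.14 log units; within the scatter). At this position, a group with one aromatic ring and a nitrile and a group with two aromatic rings therefore cannot be told apart. No measured evidence bears on this result.

Open, from the compounds shown here alone, is whether a plain phenyl, a carboxylic acid or an amine in place of the nitrile would read the same as compound 4. Also open, going by these compounds, is whether the same holds for 3-cyanophenyl at this position.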